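Trifluoromethyl in place of chloro on an anilide

The compounds below may be only part of what the source reports. "The series", "measured", "known", "first", "only" and "open" are said of these compounds alone.

In an ADME assay on THP-1 cells (Homo sapiens) for cytotoxicity, read by WST assay, with a stated time of 24 h (a higher number here means a weaker inhibitor, a lower number a stronger inhibitor), the measured compounds stand as follows.
Compound 1 `COc1ccccc1NC(=O)c1ccc2cccc(O)c2n1` gives > 30000 nM, a limit of the assay.
Compound 2 `Cc1ccccc1NC(=O)c1ccc2cccc(O)c2n1` gives > 30000 nM, a limit of the assay.
Compound 3 `O=C(Nc1ccccc1Cl)c1ccc2cccc(O)c2n1` gives > 30000 nM, a limit of the assay.

Compound 3 thus stands at the shared limit, (the limit of > 30000 nM in this assay, at which 3 of the 3 values shown sit). The steps a step that the two limits leave unreadable from compound 1 to compound 2, a step that the two limits leave unreadable from compound 1 to compound 3 and a step that the two limits leave unreadable from compound 2 to compound 3 are all unreadable. Compound 4 `O=C(Nc1ccccc1C(F)(F)F)c1ccc2cccc(O)c2n1` differs from compound 3 by trifluoromethyl in place of chloro on an aromatic carbon. For the measured compounds named here, no measured step bears readably on this change, and none of the three values leaves the limit. Compound 4 is therefore expected to sit at the limit as well, estimated at 40000 nM with a range from 15000 nM to 100000 nM. The expected step that the limit leaves unreadable from compound 3 to compound 4 is no step beyond the scatter.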

Compound 4, half-maximal inhibitory concentration: > 30000 nM
Compound 4: only a limit was reported; the forecaster's own chance of this, stated with the estimate: 85%; the middle value is on the limit's open side.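

No step from compound 1, compound 2 or compound 3 to compound 4 can be read in this assay, since all four sit at a limit: the limit of > 30000 nM in this assay, at which 4 of the 4 values shown sit.

The compounds shown leave open whether any change to this anilide would give a readable value in this assay.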